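Aryl ether series: cytotoxicity notes, compound 3 to compound 4

The source may report more compounds than this note shows. Statements on the series, on what has been measured and on what is new or still open speak of the compounds shown alone.

Measured compounds in an ADME assay on MT4 cells (Homo sapiens) for cytotoxicity, read by MTT assay, with a stated time of 4 days; a higher number here means that more compound is tolerated, a lower number that less compound is tolerated:
compound 1 `CCOc1cc(C#N)cc(OCC)c1Oc1nc(Nc2ccc(C#N)cc2)nc2ccccc12` gives 108000 nM
compound 2 `CCCOc1cc(C#N)cc(OCC)c1Oc1nc(Nc2ccc(C#N)cc2)nc2ccccc12` gives 123000 nM
compound 3 `N#Cc1ccc(Nc2nc(Oc3ccc(Cl)cc3)c3ccccc3n2)cc1` gives 198000 nM

Compound 3 holds the largest of the three numbers in this assay, but the gap to compound 2 and the gap to compound 1 are both within the scatter, so the three compounds are not separable on these data. For the measured compounds named here, the only step between measured compounds that differ in one place is a 1.1-fold higher number from compound 1 to compound 2 (0.06 log units; within the scatter), a change on the alkoxy chain of the shared core; it does not touch the aryl ether that is varied here.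

Compound 4 `Cc1ccccc1Oc1nc(Nc2ccc(C#N)cc2)nc2ccccc12` differs from compound 3 by 2-methylphenyl in place of 4-chlorophenyl on an oxygen on an aromatic ring. Going by the values given here, no measured step bears directly on this change, and the one step available was within the scatter, so no step beyond the scatter is expected in this assay for compound 4, in either direction. The estimated step is a 1.2-fold lower number from compound 3 to compound 4 (0.07 log units; within the scatter). Compound 4 is therefore expected to give about 170000 nM in this assay, with a range from 70000 nM to 400000 nM.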

Compound 4, half-maximal cytotoxic concentration: 355000 nM
The estimate for compound 4 lay 2.1-fold (0.32 log units) below the measured number; low and high end bracket the measured number.
By their numbers in this assay, from the lowest: compounds 1, 2, 3 and 4 (each within the scatter of the next, the first and the last beyond it).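

This position now has its first direct reading in this assay: 2-methylphenyl in place of 4-chlorophenyl on an oxygen on an aromatic ring gives a 1.8-fold higher number from compound 3 to compound 4 (0.25 log units; within the scatter), so this change of the aryl ether does not separate the two compounds. The step replaces the chlorine-bearing group with one of carbon only, at an equal heavy-atom count, and alters both the substituent and its numbered place on the phenyl ring, so the two alterations cannot be read apart here. No measurement is available that bears on the origin of this step.

Open is whether the substituent or its place matters, since the compounds shown include neither 2-chlorophenyl nor 4-methylphenyl. Also open, from the compounds shown here alone, is how a phenyl ring carrying an amine or a carboxylic acid at this position would read in this assay.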